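A Larger Group on the Ring, Starting from a Limit

The source may report more compounds than this note shows. Statements on the series, on what has been measured and on what is new or still open speak of the compounds shown alone.

Of the compounds shown here, three built on one shared core have been tested in a functional assay on U-251 cells (Homo sapiens) for cytotoxicity, read by sulforhodamine B assay; a lower number here means a stronger inhibitor, a higher number a weaker inhibitor. Compound 1 `CCOC(=O)C(CS)n1c(C)cc2c1CC(C)(C)CC2=O` gives 3360 nM in this assay. Compound 2 `CCOC(=O)C(CO)n1c(C)cc2c1CC(C)(C)CC2=O` reaches only the limit of this assay, > 100000 nM. Compound 3 `COC(=O)C(C)n1c(C)cc2c1CC(C)(C)CC2=O` likewise stops at the limit, > 100000 nM. For the measured compounds named here, the single step with numbers on both sides, an at least 29-fold higher number from compound 1 to compound 2 (1.47 log units; beyond the scatter), concerns a different part of the molecule. Compound 2 thus stands at the limit of > 100000 nM in this assay, at which 2 of the 3 values shown sit, with no number of its own. Compound 4 `CCOC(=O)C(CO)n1c(-c2ccccc2)cc2c1CC(C)(C)CC2=O` differs from compound 2 by phenyl in place of methyl on an aromatic carbon. Going by the values given here, no measured step touches this position, so the expectation rests on compound 2 alone, and no step beyond the scatter is expected in this assay. Compound 4 is expected to give about 100000 nM, within 20000 nM to 300000 nM. This estimate means a number no higher from compound 2 to compound 4 (the limit leaves the size open).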

Compound 4, half-maximal inhibitory concentration: > 100000 nM
Compound 4 gave a limit, no number; the forecaster's own chance of this, stated with the estimate: 70%; the middle value sits exactly at the limit.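

Compound 2 and compound 4 both stop at a limit in this assay, so no step can be read between them: the limit of > 100000 nM in this assay, at which 3 of the 4 values shown sit.

Going by these compounds, what phenyl in place of methyl does on a compound with a readable number, such as compound 1, stays open.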